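The source may report more compounds than this note shows. Statements on the series, on what has been measured and on what is new or still open speak of the compounds shown alone.

The measured compounds and their values:

compound 1, `CCc1nc2nc(C)cc(Nc3ccc(Cl)cc3)n2n1`: 86.1%
compound 2, `Cc1cc(Nc2ccc(S(F)(F)(F)(F)F)cc2)n2nc(C(C)(F)F)nc2n1`: 97.4%
compound 3, `CCC(F)(F)c1nc2nc(C)cc(Nc3ccc(S(F)(F)(F)(F)F)cc3)n2n1`: 97.7%

All three were tested in an ADME assay on a cell-free system (plasma, Homo sapiens) for protein binding. Compound 1 has the highest unbound fraction of the three, and both compound 2 and compound 3 lie beyond the scatter from it. The difference between the core of compound 1 and the core of compound 2 is not broken down here. Compound 3 differs from compound 2 by methyl in place of hydrogen on a saturated chain carbon, two bonds along the chain from an aromatic carbon and two fluorine atoms, and that change gave a 1.1-fold lower unbound fraction from compound 2 to compound 3 (0.05 log units; within the scatter).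

The unmeasured compound 4, `Cc1cc(Nc2ccc(Cl)cc2)n2nc(C(C)C)nc2n1`, differs from compound 1 by methyl in place of hydrogen on a saturated chain carbon bound to an aromatic carbon and a saturated chain carbon. Within the data shown here, it is the same kind of change as the one from compound 2 to compound 3, but not the same: there the methyl enters two bonds along the chain from an aromatic carbon and two fluorine atoms, whereas here it enters on a saturated chain carbon bound to an aromatic carbon and a saturated chain carbon.

The step expected from compound 1 to compound 4 is a 1.3-fold lower unbound fraction from compound 1 to compound 4 (0.10 log units; within the scatter), a small one, resting on a 1.1-fold lower unbound fraction from compound 2 to compound 3 (0.05 log units; within the scatter). For compound 4 the estimated value in this assay is 89%, likely between 81% and 94%.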

Compound 4, plasma protein binding in the plasma assay: 84.9%
For compound 4 the middle estimate is 1.4-fold (0.14 log units) (unbound fraction) below the measured one; the measured number falls inside the stated range.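

In the plasma assay, methyl in place of hydrogen on the chain gives a 1.1-fold higher unbound fraction from compound 1 to compound 4 (0.04 log units; within the scatter), and this step agrees with the one seen for the same kind of change on the other core: the same change on two cores in the plasma assay, a 1.1-fold lower unbound fraction (0.05 log units; within the scatter) from compound 2 to compound 3 and a 1.1-fold higher unbound fraction (0.04 log units; within the scatter) from compound 1 to compound 4, 1.2-fold (0.09 log units) apart, within the scatter of two such steps. So on these two cores the change left the unbound fraction the same within the scatter, even though the methyl enters in different surroundings on each chain, but two small steps do not show that it would behave this way on every core in the series. In a physicochemical assay for solubility, at pH 6.5 (a lower number here means a less soluble compound, a higher number a more soluble compound), compound 1 gives 170000 nM and compound 4 gives 83000 nM. In the physicochemical assay the change has a step beyond the scatter, but this is a single pair on one core and shows nothing about carrying the change to a second core: the measured solubility of compound 1, 170000 nM, and of compound 4, 83000 nM, a 2.0-fold lower number (0.31 log units; beyond the scatter).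

The chains shown are all short saturated ones, with or without two fluorine atoms. On these data alone, how a longer chain or an amine in that place would compare in either read-out remains open.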